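Chloro on the anilide ring: from compound 3 to compound 4

This account rests on a few compounds, and the source may have more. Where it says the series, first, only, none or still open, it means among the compounds named here.

The study measures cytotoxicity in a functional assay on A549 cells (Homo sapiens) for cytotoxicity, read by MTT assay, with a stated time of 72 h; on this read-out lower numbers stand for stronger inhibition and higher numbers for weaker inhibition. Compound 1 `CCOC(=O)c1c(C)oc2ncnc(Nc3ccc(OCc4cccc(Cl)c4)cc3)c12` gives 513000 nM in this assay. Compound 2 `CCOC(=O)c1c(C)oc2ncnc(Nc3ccc(OCc4ccccc4)cc3)c12` reaches only the limit of this assay, > 1000000 nM, which is a limit and not a number. The two differ by one change, (chloro in place of hydrogen on an aromatic carbon), and this change gives an at least 1.9-fold lower number from compound 2 to compound 1 (0.28 log units; that floor lies within the scatter); the floor of that step comes from the limit of compound 2, as the limit of > 1000000 nM in this assay, at which 1 of the 3 values shown sits, shows.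

Compound 3 `Cc1oc2ncnc(Nc3ccccc3)c2c1C(=O)O` gives 191000 nM in this assay, the lowest of the two numbers shown, and sits a good way below compound 1. The difference between the core of compound 3 and the core of compound 2 is not broken down here.

Compound 4 `Cc1oc2ncnc(Nc3cccc(Cl)c3)c2c1C(=O)O` has not yet been measured in this assay. It differs from compound 3 by chloro in place of hydrogen on an aromatic carbon, the same change as that from compound 2 to compound 1, at the same kind of place. On that single measured step, which only sets a floor within the usual scatter, the author expects compound 4 to give a somewhat lower number than compound 3, with wide uncertainty because the step of an at least 1.9-fold lower number from compound 2 to compound 1 (0.28 log units; that floor lies within the scatter) is known only as a floor. The expected step is a 1.6-fold lower number from compound 3 to compound 4 (0.20 log units; within the scatter). The estimate for compound 4 in this assay is 120000 nM, expected to fall between 40000 nM and 400000 nM.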

Compound 4, half-maximal inhibitory concentration: 95500 nM
Estimate against measurement, compound 4: 1.3-fold (0.10 log units) above; low and high end bracket the measured number.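

In this assay, chloro in place of hydrogen on an aromatic carbon gives a 2.0-fold lower number from compound 3 to compound 4 (0.30 log units; within the scatter), so on this core the step, read alone, cannot be told apart from the scatter of repeated measurements. Set beside the same change on the other core, both steps run in the same direction, yet neither goes beyond the scatter, and the two cannot be compared exactly: the same change on two cores in this assay, an at least 1.9-fold lower number (0.28 log units; that floor lies within the scatter) from compound 2 to compound 1 and a 2.0-fold lower number (0.30 log units; within the scatter) from compound 3 to compound 4; the limit leaves it open whether they differ The pair therefore shows that the direction of the change carried over from one core to the other, but it does not show that chloro has a real effect on either core or that the size of the step is the same on both, and the earlier step remains only a floor set by the limit of compound 2, which is a limit and not a number: the limit of > 1000000 nM in this assay, at which 1 of the 4 values shown sits.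

The compounds shown leave open whether a step beyond the scatter could come from another group on the same aromatic carbon, such as fluoro, methoxy, trifluoromethyl or an amine. They also leave open whether chloro would give a comparable step at another place on the ring.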